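Adding One Chain Carbon: From Compound 2 to Compound 3

The compounds below may be only part of what the source reports. "The series", "measured", "known", "first", "only" and "open" are said of these compounds alone.

Going by the values given here, compound 2 `CN(C)C(=O)c1cc2cnc(Nc3ccc(C(=O)NCCCCCN=C=S)cc3F)nc2n1C1CCCC1` is one of two compounds measured so far. In a functional assay on NCI-H1299 cells (Homo sapiens) for inhibition, read by CCK-8 assay, with a stated time of 72 h, tested at 10 uM (on this read-out higher numbers stand for a stronger effect at the one concentration tested and lower numbers for a weaker effect), compound 2 gives 86.7%, and compound 1 `CN(C)C(=O)c1cc2cnc(Nc3ccc(C(=O)NCCCCN=C=S)cc3F)nc2n1C1CCCC1` gives 78.9%; the step of a number 7.8 percentage points higher from compound 1 to compound 2 (within the scatter) is within the scatter, so the two stand level. Compound 3 `CN(C)C(=O)c1cc2cnc(Nc3ccc(C(=O)NCCCCCCN=C=S)cc3F)nc2n1C1CCCC1` differs from compound 2 by a group of 4 heavy atoms (2 carbon, 1 nitrogen, 1 sulfur; no ring) in place of a group of 3 heavy atoms (1 carbon, 1 nitrogen, 1 sulfur; no ring), on a saturated chain carbon, five bonds along the chain from an amide-type nitrogen. Among the compounds with values here, the one step that bears on this, a number 7.8 percentage points higher from compound 1 to compound 2 (within the scatter), was the same kind of lengthening and stayed within the scatter, so no change beyond the scatter is expected in this assay. Compound 3 is therefore estimated at 87%, between 75% and 95%, a step of a number 0.3 percentage points higher from compound 2 to compound 3 (within the scatter).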

Compound 3, a percentage reported as inhibition, at one concentration (the size of the read-out at that concentration, not a potency): 77.6%
Compound 3: the middle estimate sits 9.4 percentage points above what was measured; measured number inside the range.
By their numbers in this assay, from the lowest: compounds 3, 1 and 2 (each within the scatter of the next).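

In this assay, lengthening the chain once more gives a number 9.1 percentage points lower from compound 2 to compound 3 (within the scatter), and the whole lengthening gives a number 1.3 percentage points lower from compound 1 to compound 3 (within the scatter). Across these three chain lengths, then, no step leaves the scatter, so the numbers show neither a rise nor a fall with length at this position. Nothing available here accounts for these numbers. From the compounds shown here alone, what remains open is whether a much longer chain, or an amine in place of the group that ends the chain, would move the number beyond the scatter.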